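Notes on the aryl substituent change from compound 1

The source may report more compounds than this note shows. Statements on the series, on what has been measured and on what is new or still open speak of the compounds shown alone.

Compound 1 `COc1cc2c(Oc3ccc(NC(=O)c4nn(-c5ccccc5C)c(=O)cc4C)cc3F)ccnc2cc1OCCCN1CCCC1` gives 1590 nM in a functional assay on NCI-H460 cells (Homo sapiens) for inhibition, read by MTT assay, with a stated time of 72 h (on this read-out lower numbers stand for stronger inhibition and higher numbers for weaker inhibition), the lowest of the two numbers measured. Compound 2 `COc1cc2c(Oc3ccc(NC(=O)c4nn(-c5ccccc5C)c(=O)cc4C)cc3F)ccnc2cc1OCCCN1CCN(C)CC1` gives 3420 nM in this assay, and the step of a 2.2-fold higher number from compound 1 to compound 2 (0.33 log units; beyond the scatter) concerns the amine at the end of the chain, not the aryl ring. Compound 3 `COc1cc2c(Oc3ccc(NC(=O)c4nn(-c5ccccc5OC(F)(F)F)c(=O)cc4C)cc3F)ccnc2cc1OCCCN1CCCC1` differs from compound 1 by trifluoromethoxy in place of methyl on an aromatic carbon. Going by the values given here, no measured step bears on this change, since the single step measured alters a different part of the molecule. For compound 3 in this assay the expected step is therefore a 1.1-fold higher number from compound 1 to compound 3 (0.05 log units; within the scatter), essentially none beyond the scatter, with a wide range. Compound 3 is estimated at 1800 nM, between 600 nM and 5500 nM.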

Compound 3, half-maximal inhibitory concentration: 210 nM
The estimate for compound 3 lay 8.6-fold (0.93 log units) above the measured number; measured number below the stated range.
By their numbers in this assay, from the lowest: compound 3; then compound 1; then compound 2.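

Going by these compounds alone, the first reading on the aryl substituent shows that this place, on a carbon ortho to a large group, responds strongly in this assay: 2-(trifluoromethoxy)phenyl for 2-methylphenyl gives a 7.6-fold lower number from compound 1 to compound 3 (0.88 log units; beyond the scatter). This step is larger than the amine step at the chain end, a 2.2-fold higher number from compound 1 to compound 2 (0.33 log units; beyond the scatter). Nothing at hand accounts for the gain. On these data alone, whether a methoxy or a chlorine at this place gives a similar drop remains open. So does whether the gain carries over to the 4-methylpiperazin-1-yl chain end.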